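Lengthening the Amide Substituent from Methyl to Propyl

The compounds below may be only part of what the source reports. "The series", "measured", "known", "first", "only" and "open" are said of these compounds alone.

Compound 1 `O=C(C1CC1)[C@H]1C[C@@H]2CNC[C@@H](C2)C1` gives 1300 nM in an assay on CHO cells for agonist activity at Neuronal acetylcholine receptor; alpha3/beta4 (Homo sapiens), read by FLIPR and calcium flux; on this read-out lower numbers stand for an effect already at smaller amounts and higher numbers for an effect only at larger amounts of compound.
Compound 2 `O=C(c1ccco1)[C@H]1C[C@@H]2CNC[C@@H](C2)C1` gives "not determined" (no result reported) in this assay.
Compound 3 `CNC(=O)[C@H]1C[C@@H]2CNC[C@@H](C2)C1` gives 100000 nM in this assay.

Among the two compounds with a number in this assay, compound 3 stands at the higher end, meaning it needs the larger amount to act. For the measured compounds named here, its nearest neighbour is compound 1, and the single step that connects them, a 77-fold higher number from compound 1 to compound 3 (1.89 log units; beyond the scatter), is well beyond the usual scatter. For compound 2 no result was reported, so it cannot be placed.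

Compound 4 `CCCNC(=O)[C@H]1C[C@@H]2CNC[C@@H](C2)C1` differs from compound 3 by ethyl in place of hydrogen on a saturated chain carbon bound to an amide-type nitrogen. Going by the values given here, no measured step covers a change of this kind: the only step available, a 77-fold higher number from compound 1 to compound 3 (1.89 log units; beyond the scatter), concerns swapping a cyclopropyl ketone for a methylamide and says nothing about how long the chain on the amide nitrogen may be. With the amide kept in place, the starting point is a weak one, and the expected shift is small, a 1.7-fold lower number from compound 3 to compound 4 (0.22 log units; within the scatter), with direction uncertain and possibly within the scatter. Compound 4 is therefore estimated at 60000 nM in this assay, with a plausible range from 15000 nM to 200000 nM.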

Compound 4, half-maximal effective concentration: 15000 nM
The estimate for compound 4 lay 4.0-fold (0.60 log units) above the measured number, and the stated range covers the measured number.
By their numbers in this assay, from the lowest: compound 1; then compound 4; then compound 3.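

Lengthening the chain on the amide nitrogen has a real effect in this assay: the change from methylamino to propylamino, with ethyl in place of hydrogen on a saturated chain carbon bound to an amide-type nitrogen, gives a 6.7-fold lower number from compound 3 to compound 4 (0.82 log units; beyond the scatter). For the compounds shown here, this is a modest step, but it shows that the number responds to what is carried on the amide nitrogen, which the earlier compounds could not show. Even so, propylamino does not reach what cyclopropyl gives on the same carbonyl carbon, as the large step of a 12-fold higher number from compound 1 to compound 4 (1.06 log units; beyond the scatter) shows. Nothing measured here explains why the longer chain lowers the number.

With only methyl and propyl shown on the amide nitrogen, it remains open whether the number would keep falling with a butyl or longer chain, or would turn back up. The compounds also leave open how a branched isopropyl group, a cyclopropyl group on that nitrogen, or a chain ending in an amine or a carboxylic acid would compare with propyl.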